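Ring-nitrogen aryl swaps on the shared core

The compounds below may be only part of what the source reports. "The series", "measured", "known", "first", "only" and "open" are said of these compounds alone.

Measured compounds:
compound 1 `CC(C)c1ccccc1N1CCC(C(=O)Nc2ccc3c(c2)NC(=O)CO3)CC1` — a functional assay for antagonist activity at transient receptor potential cation channel subfamily V member 1 (Homo sapiens), read by FLIPR and calcium flux; a higher number here means a weaker inhibitor, a lower number a stronger inhibitor: 180 nM
compound 2 `COc1cccc(N2CCC(C(=O)Nc3ccc4c(c3)NC(=O)CO4)CC2)c1` — this assay: 1420 nM

Compound 2 holds the highest of the two numbers in this assay; its nearest neighbour is compound 1, reached by a 7.9-fold higher number from compound 1 to compound 2 (0.90 log units; beyond the scatter), a change of the aryl group on the ring amine nitrogen only.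

Compound 3 `Cc1c(Cl)cccc1N1CCC(C(=O)Nc2ccc3c(c2)NC(=O)CO3)CC1` carries 3-chloro-2-methylphenyl in place of 3-methoxyphenyl on an amine nitrogen in a ring. For the measured compounds named here, the one measured step that bears on this position is a 7.9-fold higher number from compound 1 to compound 2 (0.90 log units; beyond the scatter), where a 2-isopropylphenyl was replaced by a 3-methoxyphenyl. The entering 3-chloro-2-methylphenyl of compound 3 is closer in kind to the 2-isopropylphenyl of compound 1 than to the 3-methoxyphenyl of compound 2, so a step back toward the number of compound 1 is expected, roughly reversing a 7.9-fold higher number from compound 1 to compound 2 (0.90 log units; beyond the scatter). For compound 3 a value of 250 nM is estimated, between 80 nM and 800 nM, which means an expected step of a 5.7-fold lower number from compound 2 to compound 3 (0.75 log units; beyond the scatter).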

Compound 3, half-maximal inhibitory concentration: 100 nM
The estimate for compound 3 lay 2.5-fold (0.40 log units) above the measured number; the range from low to high includes it.
By their numbers in this assay, from the lowest: compounds 3 and 1 (each within the scatter of the next); then compound 2.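

In this assay the exchange of 3-methoxyphenyl for 3-chloro-2-methylphenyl on the amine nitrogen in the ring gives a 14-fold lower number from compound 2 to compound 3 (1.15 log units; beyond the scatter) and so shows that the number at this position can be brought back down by an aryl group other than 2-isopropylphenyl. The step of a 1.8-fold lower number from compound 1 to compound 3 (0.26 log units; within the scatter) leaves 2-isopropylphenyl and 3-chloro-2-methylphenyl indistinguishable here, so among the three compounds only the 3-methoxyphenyl of compound 2 stands apart. Nothing measured accounts for the difference between these aryl groups.

Still open, from the compounds shown here alone, is whether the methyl or the chlorine of compound 3 matters more, which a plain 2-methylphenyl or 3-chlorophenyl group would separate. Also open, going by these compounds, is how this nitrogen would accept a non-benzene ring such as pyridyl or cyclohexyl.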